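A few compounds are considered here, and "the series" means these few. Any claim that something is new, unique, unknown or untested is made for them only; others in the source may bear on it.

Measured in a functional assay on A2780 cells (Homo sapiens) for cytotoxicity; on this read-out higher numbers stand for weaker inhibition and lower numbers for stronger inhibition:
- compound 1 `CC(=O)Nc1ncc(SCc2ncc(C(C)C)o2)s1`: 200 nM
- compound 2 `CC(=O)Nc1ncc(SCc2ncc(CC3CCCCC3)o2)s1`: 1540 nM
- compound 3 `CC(C)(C)C(=O)Nc1ncc(SCc2ncc(C(C)(C)C)o2)s1`: 250 nM

In this assay, compound 3 at 250 nM lies within the usual scatter of compound 1 at 200 nM, while compound 2 at 1540 nM has the highest number of the three, clearly beyond the scatter of both.

The next compound, compound 4 `C[C@@H](C(=O)Nc1ncc(SCc2ncc(C(C)(C)C)o2)s1)c1ccccc1`, is made from compound 3 by one change: 1-phenylethyl in place of tert-butyl on a carbonyl carbon. Put briefly, 1-phenylethyl stands in place of tert-butyl on a carbonyl carbon.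

For the measured compounds named here, no measured step covers a change at this place. Compound 1 and compound 3 differ in more than one place, and their values do not separate those changes. Going by the values given here, the only measured step, a 7.7-fold higher number from compound 1 to compound 2 (0.89 log units; beyond the scatter), puts cyclohexylmethyl in place of isopropyl on an aromatic carbon, so it bears on this change only indirectly. Taking that step as a loose guide, a modest move towards a higher number is expected, smaller than that step, though the direction is uncertain.

The expected step is a 2.2-fold higher number from compound 3 to compound 4 (0.34 log units; beyond the scatter).

Compound 4 is estimated at 550 nM, with an expected range from 140 nM to 2200 nM.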

Compound 4, half-maximal inhibitory concentration: 900 nM
Compound 4: the middle estimate sits 1.6-fold (0.21 log units) below what was measured, and the stated range covers the measured number.
By their numbers in this assay, from the lowest: compounds 1 and 3 (each within the scatter of the next); then compounds 4 and 2 (each within the scatter of the next).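

For the compounds shown here, the step at this position shows for the first time that the group on a carbonyl carbon matters on its own: in this assay, 1-phenylethyl in place of tert-butyl gives a 3.6-fold higher number from compound 3 to compound 4 (0.56 log units; beyond the scatter). The change is modest even though the entering group has 8 heavy atoms against 4 and brings a six-membered aromatic ring and a defined stereocentre, so this position accepts a much larger group and compound 4 still gives 900 nM. Nothing measured here accounts for the step, which remains an observation without an explanation.

This single pair leaves unresolved whether the step follows the aromatic ring, the added carbon count or the stereocentre, since all three enter together. Going by these compounds, it also remains open how the opposite stereoisomer of compound 4, a plain benzyl group, or a group carrying an amine or a carboxylic acid would read on this carbonyl carbon, and whether the same step would hold with isopropyl rather than tert-butyl on the other end of the molecule.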